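From benzyl to pentyl: a step near the limit

This account rests on a few compounds, and the source may have more. Where it says the series, first, only, none or still open, it means among the compounds named here.

In an ADME assay on MRC5 cells (Homo sapiens) for inhibition, with a stated time of 72 h (on this read-out lower numbers stand for an effect already at smaller amounts and higher numbers for an effect only at larger amounts of compound), compound 1 `COc1cccc(OC)c1C(=O)Nc1c[nH]nc1C(=O)NN1CCOCC1` gives > 50000 nM, which is a limit of the assay and not a number. Going by the values given here, compound 2 `COc1cccc(OC)c1C(=O)Nc1c[nH]nc1C(=O)NCc1ccccc1` gives 50000 nM, the only true number so far. Among the compounds with values here, the single measured step, a number no higher from compound 1 to compound 2 (the limit leaves the size open), puts benzyl in place of morpholin-4-yl on an amide-type nitrogen, and its size cannot be read.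

Compound 3 `CCCCCNC(=O)c1n[nH]cc1NC(=O)c1c(OC)cccc1OC` has butyl in place of phenyl on a saturated chain carbon bound to an amide-type nitrogen, which reads as benzyl to pentyl one bond further out: butyl in place of phenyl on a saturated chain carbon bound to an amide-type nitrogen. Within the data shown here, no measured step of known size bears on this change, so compound 2 with 50000 nM is the best guide, and no shift beyond the usual scatter is expected. The expected change is a 1.3-fold lower number from compound 2 to compound 3 (0.10 log units; within the scatter). With the limit of > 50000 nM in this assay, at which 1 of the 2 values shown sits, a limit reading is also quite possible for the new compound. For compound 3 the estimated value is 40000 nM, with a range of 15000 nM to 50000 nM.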

Compound 3, half-maximal effective concentration: > 50000 nM
Compound 3 was reported as a limit; the forecaster's own chance of this, stated with the estimate: 55%; middle value at least 1.2-fold (0.09 log units) from the limit.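

In this assay compound 3 gives > 50000 nM, which is a limit of the assay and not a number. Putting butyl in place of phenyl on a saturated chain carbon bound to an amide-type nitrogen gives a number no lower from compound 2 to compound 3 (the limit leaves the size open), so pentyl shows no effect at smaller amounts than benzyl does, while the pair of compound 1 and compound 3 cannot be read. This place has now carried morpholin-4-yl, benzyl and pentyl, and all three readings lie at or past the same end of the range: the limit of > 50000 nM in this assay, at which 2 of the 3 values shown sit.

Going by these compounds, whether an amine, a carboxylic acid or a longer chain on this amide-type nitrogen would give a clearly lower number stays open. Also open, on these data alone, are how far compound 3 lies past its limit and whether a change elsewhere on the shared core would move the read-out.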